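Working notes: from compound 1 to compound 4

The source may report more compounds than this note shows. Statements on the series, on what has been measured and on what is new or still open speak of the compounds shown alone.

Compound 1 `O=C(CCc1cccc2c1B(O)OC2)NCc1ccccc1` gives > 100000 nM in an ADME assay on WI-38 cells (Homo sapiens) for cytotoxicity, read by MTT assay, with a stated time of 72 h (a higher number here means a weaker inhibitor, a lower number a stronger inhibitor), which is a limit of the assay and not a number. Compound 2 `CC(C)(C)OC(=O)Nc1ccc(NC(=O)CCc2cccc3c2B(O)OC3)cc1` gives > 100000 nM, also a limit. Compound 3 `CCOC(=O)c1ccc(NC(=O)CCc2cccc3c2B(O)OC3)cc1` gives > 100000 nM, again a limit. Compound 1 therefore has no exact standing in this series.

The change to compound 4 `O=C(CCc1cccc2c1B(O)OC2)Nc1cccc(Br)c1` is 3-bromophenyl in place of benzyl on an amide-type nitrogen. Among the compounds with values here, the only measured step, a step that the two limits leave unreadable from compound 2 to compound 3, lies at a different place and offers no size to carry over. The expectation for this assay rests instead on compound 1, compound 2 and compound 3 together: the limit of > 100000 nM in this assay, at which 3 of the 3 values shown sit. No step beyond the scatter is expected, and no direction can be assigned. The estimated step is a number no higher from compound 1 to compound 4 (the limit leaves the size open). For compound 4 the expected value is 100000 nM. The estimated range for compound 4 runs from 50000 nM to 200000 nM.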

Compound 4, half-maximal inhibitory concentration: 20000 nM
Compound 4: the middle estimate sits 5.0-fold (0.70 log units) above what was measured; the measured number lies below the stated range.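

In this assay, within the data shown here, compound 4 gives 20000 nM, the first exact number, so a change on the amide-type nitrogen can bring this read-out to an exact number. Placing 3-bromophenyl where benzyl stood gives an at least 5.0-fold lower number from compound 1 to compound 4 (0.69 log units; beyond the scatter), and the two groups match in their counts of heavy atoms, hydrogen-bond donors and hydrogen-bond acceptors, so those counts do not separate them. This remains a single number against an otherwise flat set of results: the limit of > 100000 nM in this assay, at which 3 of the 4 values shown sit.

Still open, as far as these compounds go, is whether the step belongs to the bromine or to the replacement of benzyl by a phenyl ring, a question that an unsubstituted phenyl or a 3-chlorophenyl on the same nitrogen would address. The step from compound 2 to compound 3 cannot be read, so it adds nothing on size.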